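The source may report more compounds than this note shows. Statements on the series, on what has been measured and on what is new or still open speak of the compounds shown alone.

Measured compounds:
compound 1, `Oc1ccc(CNc2cc(C(F)(F)F)cc3[nH]ncc23)cc1`, 75%
compound 2, `Oc1ccc(CNc2cc(C(F)(F)F)cc3[nH]ncc23)c(Cl)c1`, 92%
compound 3, `FC(F)(F)c1cccc(CNc2cc(C(F)(F)F)cc3[nH]ncc23)c1`, 40%

In an assay for inhibition of Tryptophan 2,3-dioxygenase (Homo sapiens), with stated times of 10 min and 60 min, tested at 10 uM (a higher number here means a stronger effect of the compound at the concentration tested, a lower number a weaker effect), compound 1 stands second highest of the three numbers. Compound 2 lies above it, the step of a number 17 percentage points higher from compound 1 to compound 2 (beyond the scatter) being beyond the scatter, while compound 3 gives 40%, a clearly lower number than compound 1 with 75%. Compound 4, `FC(F)(F)c1cc(NC[C@H]2CCCCN2)c2cn[nH]c2c1`, differs from compound 1 as follows: piperidin-2-yl in place of 4-hydroxyphenyl on a saturated chain carbon bound to a nitrogen on an aromatic ring. Going by the values given here, the one measured step, from compound 1 to compound 2, concerns a chloro on the aromatic ring and does not touch the group that leaves here, so it bears on this change only loosely. The two values of compounds 1 and 3 show that exchanging the 4-hydroxyphenyl can lower the number markedly. For compound 4 a lower number is therefore expected, as the step of a number 25 percentage points lower from compound 1 to compound 4 (beyond the scatter), with an estimate of 50% and a likely range from 20% to 80%.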

Compound 4, a percentage reported as inhibition, at one concentration (the size of the read-out at that concentration, not a potency): 69%
The estimate for compound 4 lay 19 percentage points below the measured number; low and high end bracket the measured number.
By their numbers in this assay, from the lowest: compound 3; then compounds 4 and 1 (each within the scatter of the next); then compound 2.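

In this assay, putting piperidin-2-yl in place of 4-hydroxyphenyl on a saturated chain carbon bound to a nitrogen on an aromatic ring gives a number 6 percentage points lower from compound 1 to compound 4 (within the scatter). At this position, then, an aromatic ring of carbon only is not needed to hold the read-out, since a six-membered non-aromatic ring does so as well. Nothing available explains why the two groups read alike. The compounds shown leave open whether the ring nitrogen of piperidin-2-yl matters, which a cyclohexyl group would test. They also leave open whether the defined stereocentre matters, which the opposite enantiomer would test.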